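The source may hold more compounds than are shown below. What is called first, only, known or untested is meant among the compounds shown, and "the series" means these compounds.

In a functional assay on HT-29 cells (Homo sapiens) for cytotoxicity, read by MTT assay, with a stated time of 3 days (a lower number here means a stronger inhibitor, a higher number a weaker inhibitor), compound 1 `Oc1ccc(-c2cccc(O)c2)cc1` gives 3.4 ug/mL, and compound 2 `Nc1cccc(-c2ccc(O)cc2)c1` gives 5.4 ug/mL. The change amino in place of hydroxy on an aromatic carbon made a 1.6-fold higher number from compound 1 to compound 2 (0.20 log units; within the scatter). Compound 3 `COc1ccc(-c2ccc(O)cc2)cc1OC` gives 26 ug/mL in this assay, the highest of the three numbers. The difference between the core of compound 3 and that of compound 1 is not broken down here. Compound 4 `COc1ccc(-c2ccc(N)cc2)cc1OC` carries the change amino in place of hydroxy on an aromatic carbon on the core of compound 3. The place is not identical: the earlier change sat meta to a group of 7 heavy atoms, this one para to a large group, so it is the same kind of change rather than the same change. For compound 4 a step of a 1.3-fold higher number from compound 3 to compound 4 (0.13 log units; within the scatter) is expected, because the earlier step was a 1.6-fold higher number from compound 1 to compound 2 (0.20 log units; within the scatter). Compound 4 is therefore estimated at 35 ug/mL, between 15 ug/mL and 80 ug/mL.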

Compound 4, half-maximal inhibitory concentration: 2 ug/mL
Estimate against measurement, compound 4: 18-fold (1.24 log units) above; the whole stated range lies above it.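

In this assay amino in place of hydroxy on an aromatic carbon made a 13-fold lower number from compound 3 to compound 4 (1.11 log units; beyond the scatter) and did not repeat the earlier step: the same change on two cores in this assay, a 1.6-fold higher number (0.20 log units; within the scatter) from compound 1 to compound 2 and a 13-fold lower number (1.11 log units; beyond the scatter) from compound 3 to compound 4, 21-fold (1.31 log units) apart, beyond the scatter of two such steps. In these two pairs, then, the step seen on one core did not carry over to the other. The pairs do not show why the steps part, as both the core and the place of the change differ between them, and two pairs give no rule for any further core.

Still open, going by these compounds, is whether an acetamide or a carboxylic acid at that place on the core of compound 3 would keep the low number of compound 4. Also open, on these data alone, is how amino compares with hydroxy on a core bearing a single methoxy group.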